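Sulfonyl substituent swap on the shared core

The source may hold more compounds than are shown below. What is called first, only, known or untested is meant among the compounds shown, and "the series" means these compounds.

Measured so far in a functional assay on K562 cells (Homo sapiens) for inhibition, read by trypan blue exclusion, with a stated time of 72 h; a higher number here means a weaker inhibitor, a lower number a stronger inhibitor:
compound 1 `Cn1c(=O)c(C(=O)Nc2ccc(F)cc2F)cc2cnc(Nc3ccc4[nH]ccc4c3)nc21`: 5000 nM
compound 2 `COc1ccc(S(=O)(=O)c2cc3cnc(Nc4ccc5[nH]ccc5c4)nc3n(C)c2=O)cc1`: 300 nM
compound 3 `Cn1c(=O)c(S(=O)(=O)Nc2ccc(F)cc2)cc2cnc(Nc3ccc4[nH]ccc4c3)nc21`: 5000 nM

Compound 3 stands level with compound 1 at the digits printed, the two together the highest numbers of the three; compound 2 sits a 17-fold higher number from compound 2 to compound 3 (1.22 log units; beyond the scatter) apart from it. Compound 4 `Cn1c(=O)c(S(=O)(=O)c2ccc(Cl)cc2Cl)cc2cnc(Nc3ccc4[nH]ccc4c3)nc21` differs from compound 3 by 2,4-dichlorophenyl in place of (4-fluorophenyl)amino on a sulfonyl sulfur. Among the measured compounds shown here, the only step bearing on this is the one on the same sulfonyl sulfur, a 17-fold higher number from compound 2 to compound 3 (1.22 log units; beyond the scatter), where an aryl group gave way to an arylamino group and the number rose. Going by these compounds, compound 4 reverses that direction back to an aryl group, so a lower number, of a similar size, is expected, though the two chlorines are untested. Compound 4 is estimated at 600 nM (range 150 nM to 3000 nM), a step of an 8.3-fold lower number from compound 3 to compound 4 (0.92 log units; beyond the scatter).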

Compound 4, half-maximal inhibitory concentration: 1000 nM
Estimate against measurement, compound 4: 1.7-fold (0.22 log units) below, and the stated range covers the measured number.
By their numbers in this assay, from the lowest: compound 2; then compound 4; then compounds 1 and 3 (each within the scatter of the next).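

In this assay, a second aryl group on the sulfonyl sulfur again beats the arylamino group, with a 5.0-fold lower number from compound 3 to compound 4 (0.70 log units; beyond the scatter) as a smaller step than the earlier one. The gain is not tied to 4-methoxyphenyl, although 2,4-dichlorophenyl in its place gives a 3.3-fold higher number from compound 2 to compound 4 (0.52 log units; beyond the scatter) on the same sulfur. On the aromatic carbon, (2,4-dichlorophenyl)sulfonyl also improves on (2,4-difluorophenyl)carbamoyl, with a 5.0-fold lower number from compound 1 to compound 4 (0.70 log units; beyond the scatter) between them.

Nothing available explains these steps. Open, going by these compounds, is how a single chlorine, an amine or a carboxylic acid on that aryl ring would read.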